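This account rests on a few compounds, and the source may have more. Where it says the series, first, only, none or still open, it means among the compounds named here.

Working notes on the series. Compound 1 `O/N=C(\CCN1CCN(c2ccccn2)CC1)c1ccccc1` is the unsubstituted phenyl member; in a functional assay on HEK293 cells with D(4) dopamine receptor (Homo sapiens) as the target, read by FLIPR (on this read-out lower numbers stand for an effect already at smaller amounts and higher numbers for an effect only at larger amounts of compound), compound 1 gives 4.4 nM. Compound 2 `O/N=C(\CCN1CCN(c2ccccn2)CC1)c1ccccc1Cl` carries chloro on the phenyl ring; in this assay compound 2 gives 24 nM, the highest of the two numbers recorded so far. Among the compounds with values here, the only step recorded is a 5.5-fold higher number from compound 1 to compound 2 (0.74 log units; beyond the scatter).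

Compound 3 `Cc1ccccc1/C(CCN1CCN(c2ccccn2)CC1)=N/O` differs from compound 2 by methyl in place of chloro on an aromatic carbon. Within the data shown here, no recorded step swaps one small group on this ring for another; the only step that touches this position is the one from compound 1 to compound 2, in which adding chloro raised the number modestly. With a single heavy atom leaving and a single heavy atom entering at the same place, the step in this assay from compound 2 to compound 3 is expected to be small, a 1.3-fold lower number from compound 2 to compound 3 (0.12 log units; within the scatter), with no clear direction beyond the scatter. Compound 3 is therefore expected to give about 18 nM, within 6 nM to 55 nM.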

Compound 3, half-maximal effective concentration: 4.2 nM
Compound 3: middle estimate off by 4.3-fold (0.63 log units), on the high side, outside the stated range (below it).
By their numbers in this assay, from the lowest: compounds 3 and 1 (each within the scatter of the next); then compound 2.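

Going from 2-chlorophenyl to 2-methylphenyl gives a 5.7-fold lower number from compound 2 to compound 3 (0.76 log units; beyond the scatter) in this assay and shows that exchanging one small group for another at this place can move the number beyond the scatter. Methyl in place of hydrogen gives a 1.0-fold lower number from compound 1 to compound 3 (0.02 log units; within the scatter) and leaves compound 3 within the scatter of compound 1, so a group at this place does not in itself raise the number; among the three compounds, only chloro in compound 2 does. Nothing available accounts for the difference between chloro and methyl here.

As far as these compounds go, it remains open whether fluoro, bromo or methoxy at this place would track chloro or methyl. From the compounds shown here alone, it also remains open whether methyl on another carbon of the phenyl ring would match the result for compound 3.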